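Bromo for methyl on two related cores

This account rests on a few compounds, and the source may have more. Where it says the series, first, only, none or still open, it means among the compounds named here.

The measured compounds are:
compound 1, `Cc1ccccc1/C=C1\CCc2ccccc2C1=O`, giving 43200 nM;
compound 2, `O=C1/C(=C/c2ccccc2Br)CCc2ccccc21`, giving 25400 nM;
compound 3, `Cc1ccccc1/C=C1\Cc2ccccc2C1=O`, giving 56500 nM.

All three were tested in a functional assay on CCRF-CEM cells (Homo sapiens) for inhibition; a lower number here means a stronger inhibitor, a higher number a weaker inhibitor. Compound 1 and compound 2 share one core and differ by bromo in place of methyl on an aromatic carbon, a change that gave a 1.7-fold lower number from compound 1 to compound 2 (0.23 log units; within the scatter). Compound 3 sits on a second core; how that core differs from the core of compound 1 is not broken down here. Within this assay compound 3 and compound 1 lie within the scatter of each other, while compound 3 gives a higher number than compound 2, a gap beyond the scatter.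

Compound 4, `O=C1/C(=C/c2ccccc2Br)Cc2ccccc21`, is the unmeasured partner of compound 3. It carries the same change, (bromo in place of methyl on an aromatic carbon), at the same kind of place. Because the earlier step was a 1.7-fold lower number from compound 1 to compound 2 (0.23 log units; within the scatter), the step from compound 3 to compound 4 is expected to be of like size, namely a 1.7-fold lower number from compound 3 to compound 4 (0.23 log units; within the scatter). On that basis compound 4 is estimated at 33000 nM in this assay, with a range of 15000 nM to 75000 nM.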

Compound 4, half-maximal inhibitory concentration: 46800 nM
The estimate for compound 4 lay 1.4-fold (0.15 log units) below the measured number, within the range that was stated.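

On the second core, bromo in place of methyl on an aromatic carbon gave a 1.2-fold lower number from compound 3 to compound 4 (0.08 log units; within the scatter) in this assay. Set beside the step on the first core, the change carried from one core to the other with no difference that stands out from the scatter: the same change on two cores in this assay, a 1.7-fold lower number (0.23 log units; within the scatter) from compound 1 to compound 2 and a 1.2-fold lower number (0.08 log units; within the scatter) from compound 3 to compound 4, 1.4-fold (0.15 log units) apart, within the scatter of two such steps. Within the data shown here, both steps lie within the scatter themselves, so the pair shows only that this swap left the number about where it was on each of two cores; it does not show that bromo and methyl differ in this cell read-out on either core, and it says nothing about how the change would behave on any third core.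

The compounds shown leave open whether a different group at that place on the aromatic ring, such as a methoxy, an amine or a carboxylic acid, would give a step beyond the scatter. They also leave open what a group on another carbon of that ring would do on either core.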